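This account rests on a few compounds, and the source may have more. Where it says the series, first, only, none or still open, it means among the compounds named here.

Measured compounds in a functional assay on HT-29 cells (Homo sapiens) for inhibition, read by MTT assay, with a stated time of 72 h; a lower number here means a stronger inhibitor of growth, a higher number a weaker inhibitor of growth:

compound 1 `O=S(=O)(NCCCNCc1ccccc1Cl)c1cc(C(F)(F)F)cc(C(F)(F)F)c1` gives 20000 nM
compound 2 `O=S(=O)(NCCCNCc1ccc(Cl)c(C(F)(F)F)c1)c1cc(C(F)(F)F)cc(C(F)(F)F)c1` gives 11000 nM
compound 3 `COc1cccc(CNCCCNS(=O)(=O)c2cc(C(F)(F)F)cc(C(F)(F)F)c2)c1` gives 10000 nM

Compound 3 has the lowest of the three numbers, but its lead is slight: compound 2 sits a 1.1-fold lower number from compound 2 to compound 3 (0.04 log units; within the scatter) and compound 1 sits a 2.0-fold lower number from compound 1 to compound 3 (0.30 log units; within the scatter), both within the scatter, so the three compounds cannot be separated in this assay. The remaining step is likewise within the scatter: a 1.8-fold lower number from compound 1 to compound 2 (0.26 log units; within the scatter).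

Compound 4 `COc1ccccc1CNCCCNS(=O)(=O)c1cc(C(F)(F)F)cc(C(F)(F)F)c1` differs from compound 3 only in the aryl group: 2-methoxyphenyl in place of 3-methoxyphenyl on a saturated chain carbon bound to an amine nitrogen. For the measured compounds named here, the step that comes closest to this is the one from compound 1 to compound 3, where a 2-chlorophenyl gave way to a 3-methoxyphenyl at the same place and the number moved a 2.0-fold lower number from compound 1 to compound 3 (0.30 log units; within the scatter). That step mixes a change of substituent with a change of its position, and was itself within the scatter. Going by the values given here, nothing among the measured compounds points to a step beyond the scatter for moving the methoxy group, so compound 4 is expected to stay close to compound 3, with a 1.4-fold higher number from compound 3 to compound 4 (0.15 log units; within the scatter) as the estimated step. For compound 4 the expected value in this assay is 14000 nM, within the range 6000 nM to 35000 nM.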

Compound 4, concentration for 50% growth inhibition: 12000 nM
The estimate for compound 4 lay 1.2-fold (0.07 log units) above the measured number; the measured number falls inside the stated range.
By their numbers in this assay, from the lowest: compounds 3, 2, 4 and 1 (each within the scatter of the next).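

In this assay, for the compounds shown here, compound 3 and compound 4 form the first pair in which only the position of the methoxy group changes, and the step (a 1.2-fold higher number from compound 3 to compound 4 (0.08 log units; within the scatter)) shows that going from 3-methoxyphenyl to 2-methoxyphenyl does not separate them. The exchange of methoxy for chloro on an aromatic carbon also appears here as a single change (a 1.7-fold lower number from compound 1 to compound 4 (0.22 log units; within the scatter)), and the step to the 4-chloro-3-(trifluoromethyl)phenyl compound is equally small (a 1.1-fold higher number from compound 2 to compound 4 (0.04 log units; within the scatter)), so all of these steps lie within the scatter. No supporting measurement is available to explain how close these aryl groups remain.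

Going by these compounds, whether a carboxylic acid or an amine on the aryl ring would give a step beyond the scatter remains open. So does the effect of a longer chain in the shared core.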